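The source may report more compounds than this note shows. Statements on the series, on what has been measured and on what is new or still open speak of the compounds shown alone.

Compound 1, `CCN1C(=O)CN(Cc2ccc(-c3cccc(CN4CCCCC4)n3)cc2)C1=O`, gives 2 h in an in vitro ADME assay on microsomes from liver (Homo sapiens) for metabolic stability, read by LC-MS, using NADPH, tested at 1 uM; a higher number here means that the compound lasts longer, a lower number that the compound disappears faster.
Compound 2, `O=C1CN(Cc2ccc(-c3ccc(F)c(CN4CCCCC4)n3)cc2)C(=O)N1CC1CCC1`, gives 0.0833 h in this assay.
Compound 3, `CC(C)CN1C(=O)CN(Cc2ccc(-c3ccc(F)c(CN4CCCC(C)C4)n3)cc2)C1=O`, gives 0.1 h in this assay.

Compound 2 has the lowest of the three half-lives in this assay; compound 3 sits within the usual scatter of it, while compound 1 lies far higher, well beyond the scatter. Compound 4, `CC(C)CN1C(=O)CN(Cc2ccc(-c3ccc(F)c(CN4CCCCC4)n3)cc2)C1=O`, differs from compound 2 in one place: isopropyl in place of cyclobutyl on a saturated chain carbon bound to an amide-type nitrogen in a ring. Among the measured compounds shown here, no measured pair shows this exact change, so its effect is open. Compound 3, which also carries isobutyl, gives 0.1 h in this assay, and compound 4 is therefore expected to stay close to compound 2, with a step of a 1.2-fold higher number from compound 2 to compound 4 (0.08 log units; within the scatter) that probably does not rise beyond the scatter. Compound 4 is estimated at 0.1 h, with a range from 0.05 h to 0.25 h.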

Compound 4, half-life: 0.217 h
Beside the measured number, compound 4's estimate is 2.2-fold (0.34 log units) below it, and the stated range covers the measured number.
By their numbers in this assay, from the lowest: compounds 2 and 3 (each within the scatter of the next); then compound 4; then compound 1.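

In this assay, isopropyl in place of cyclobutyl on this saturated chain carbon gives a 2.6-fold higher number from compound 2 to compound 4 (0.42 log units; beyond the scatter), so this position does respond to the change, though only modestly. Hydrogen in place of methyl on a saturated ring carbon gives a 2.2-fold higher number from compound 3 to compound 4 (0.34 log units; beyond the scatter), which shows that this second place matters as well. Nothing shown explains either step.

From the compounds shown here alone, whether a longer chain or an ether oxygen on the chain carbon would shift the half-life further stays open. So does whether swapping cyclobutyl for isopropyl has the same effect with that ring methyl present.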